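Swapping a pyridinyl for a methylphenyl on the shared core

This account rests on a few compounds, and the source may have more. Where it says the series, first, only, none or still open, it means among the compounds named here.

Measured so far, in a functional assay on DU-145 cells (Homo sapiens) for cytotoxicity, in the presence of a further agent that is not named here; on this read-out higher numbers stand for weaker inhibition and lower numbers for stronger inhibition:
compound 1 `Clc1cccc(-c2cc(-c3ccc(Cl)o3)cc(-c3cccs3)n2)c1`: 18100 nM
compound 2 `Clc1ccc(-c2cc(-c3ccoc3)cc(-c3cccs3)n2)cc1`: 21100 nM
compound 3 `Clc1ccc(-c2cc(-c3ccsc3)nc(-c3ccccn3)c2)o1`: 10900 nM

The three numbers are all close. Compound 3 has the lowest of them, yet its gaps to compound 1 and to compound 2 both lie within the scatter of repeated measurements, so no order among the three can be read from these values.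

Compound 4 `Cc1ccccc1-c1cc(-c2ccc(Cl)o2)cc(-c2ccsc2)n1` has not yet been measured. It differs from compound 3 in one place: 2-methylphenyl in place of pyridin-2-yl on an aromatic carbon. For the measured compounds named here, no pair of measured compounds differs in just one place, so there is no measured step to guide an expectation for this exchange.

Going by the values given here, with only three closely grouped values and no single-point comparison to lean on, the expectation for compound 4 is a number near that of compound 3, with the step of a 1.4-fold higher number from compound 3 to compound 4 (0.14 log units; within the scatter) expected to stay within the scatter rather than go clearly in either direction. Compound 4 is therefore estimated at 15000 nM, in a range from 6000 nM to 40000 nM.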

Compound 4, half-maximal inhibitory concentration: 24800 nM
Estimate against measurement, compound 4: 1.7-fold (0.22 log units) below, and the stated range covers the measured number.
By their numbers in this assay, from the lowest: compounds 3, 1, 2 and 4 (each within the scatter of the next, the first and the last beyond it).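

In this assay, for the compounds shown here, the exchange of pyridin-2-yl for 2-methylphenyl, next to the ring nitrogen, gives a 2.3-fold higher number from compound 3 to compound 4 (0.36 log units; beyond the scatter) and offers the first single-place comparison here. The step is modest, but it shows that the group at this position can shift the number beyond the scatter. The exchange removes the pyridinyl nitrogen and adds a methyl together, so this one step cannot separate the two. No measured evidence explains the step. As far as these compounds go, whether plain phenyl would sit nearer compound 3 or compound 4 stays open, as does the outcome with an aminophenyl or carboxyphenyl group here.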